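The source may hold more compounds than are shown below. What is called first, only, known or untested is meant among the compounds shown, and "the series" means these compounds.

Working notes on the aminopyrimidine series. Compound 1 `Cc1cccc(Nc2nc(SCc3cn(Cc4ccccc4Cl)nn3)nc(-c3ccccc3)c2C#N)c1` gives, in a functional assay on MGC-803 cells (Homo sapiens) for inhibition, read by MTT assay, with a stated time of 72 h (a lower number here means a stronger inhibitor, a higher number a weaker inhibitor), a value of 16200 nM. Among the measured compounds shown here, compound 2 `N#Cc1c(Nc2cccc([N+](=O)[O-])c2)nc(SCc2cn(Cc3ccccc3Cl)nn2)nc1-c1ccccc1` gives 43100 nM in this assay, which is the highest of the two numbers measured so far; the only step recorded, a 2.7-fold higher number from compound 1 to compound 2 (0.42 log units; beyond the scatter), came with nitro in place of methyl on an aromatic carbon.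

Compound 3 `N#Cc1c(Nc2ccc(F)cc2)nc(SCc2cn(Cc3ccccc3Cl)nn2)nc1-c1ccccc1` is not yet measured. It differs from compound 2 in one place: 4-fluorophenyl in place of 3-nitrophenyl on a nitrogen on an aromatic ring. For the measured compounds named here, the one measured step that bears on this is the one from compound 1 to compound 2, where the nitro entered and the number rose; compound 3 removes that nitro again, while the fluorine has no measured precedent. A modest fall in the number is therefore expected, back toward the range of compound 1, as a 2.4-fold lower number from compound 2 to compound 3 (0.38 log units; beyond the scatter). The estimate for compound 3 in this assay is 18000 nM, with a range from 7000 nM to 45000 nM.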

Compound 3, half-maximal inhibitory concentration: 8740 nM
For compound 3 the middle estimate is 2.1-fold (0.31 log units) above the measured one, and the stated range covers the measured number.
By their numbers in this assay, from the lowest: compounds 3 and 1 (each within the scatter of the next); then compound 2.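

Working from this assay, 4-fluorophenyl in place of 3-nitrophenyl on the nitrogen gives a 4.9-fold lower number from compound 2 to compound 3 (0.69 log units; beyond the scatter) and sets compound 2 apart from compound 3. Against 3-methylphenyl, the same 4-fluorophenyl gives a 1.9-fold lower number from compound 1 to compound 3 (0.27 log units; within the scatter) and so does not separate the two compounds, which leaves 3-nitrophenyl as the only one of the three groups at this place with a distinct number. No measurement to hand bears on what lies behind the number of compound 2.

The series compares only 3-substituted groups with a 4-substituted one, so the place on the phenyl ring and the identity of the group change together. Going by these compounds, whether an amine or a carboxylic acid on this phenyl ring, or cyclohexyl in place of it, would move the number further remains open.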